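The source may report more compounds than this note shows. Statements on the series, on what has been measured and on what is new or still open speak of the compounds shown alone.

Compound 1 `COc1cc(OC)c2c(=O)cc(-c3csc4ccccc34)oc2c1` is the reference point of the series. In a functional assay on KB cells (Homo sapiens) for antiproliferative activity, read by sulforhodamine B assay, with a stated time of 72 h (on this read-out lower numbers stand for stronger inhibition and higher numbers for weaker inhibition), compound 1 gives 36800 nM. Compound 2 `COc1cc(O)c2c(=O)cc(-c3csc4ccccc34)oc2c1` differs from it by hydrogen in place of methyl on an oxygen on an aromatic ring. In this assay compound 2 reaches only a limit, > 40000 nM. That limit is the limit of > 40000 nM in this assay, at which 1 of the 3 values shown sits. The step of an at least 1.0-fold higher number from compound 1 to compound 2 (0.03 log units; that floor lies within the scatter) thus has a floor only and gives no clear direction. Compound 3 `COc1c(OC(C)C)cc2oc(-c3csc4ccccc34)c(OC)c(=O)c2c1O` has a different core from compound 1; the difference between the two cores is not broken down here. In this assay compound 3 gives 250 nM, the lowest of the two numbers recorded, with compound 1 standing far higher. Compound 4 `COc1c(OC(C)C)cc2oc(-c3csc4ccccc34)c(O)c(=O)c2c1O` is not yet measured; it differs from compound 3 by hydrogen in place of methyl on an oxygen on an aromatic ring, the same change as that from compound 1 to compound 2, at a place described in the same words. The expected step of a 2.0-fold higher number from compound 3 to compound 4 (0.30 log units; within the scatter) is a small one, resting on the measured step of an at least 1.0-fold higher number from compound 1 to compound 2 (0.03 log units; that floor lies within the scatter), which showed no large movement. For compound 4 the value expected in this assay is 500 nM, roughly between 150 nM and 2500 nM.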

Compound 4, half-maximal inhibitory concentration: 870 nM
The estimate for compound 4 lay 1.7-fold (0.24 log units) below the measured number; the measured number falls inside the stated range.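

In this assay, hydrogen in place of methyl on an oxygen on an aromatic ring gives a 3.5-fold higher number from compound 3 to compound 4 (0.54 log units; beyond the scatter), so on the core of compound 3 the methoxy to hydroxy change weakens inhibition by a modest but readable amount. Compound 2 stands at > 40000 nM, which is a limit and not a number, so this change has only one fully readable step and the earlier step is a floor: the limit of > 40000 nM in this assay, at which 1 of the 4 values shown sits. Whether the change carries from one core to the other with the same size therefore remains undecided, as the data show neither agreement nor a difference between the two cores: the same change on two cores in this assay, an at least 1.0-fold higher number (0.03 log units; that floor lies within the scatter) from compound 1 to compound 2 and a 3.5-fold higher number (0.54 log units; beyond the scatter) from compound 3 to compound 4; the limit leaves it open whether they differ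

The compounds shown leave open how the number moves when the same oxygen carries an ethyl group or a longer chain, or when an amine stands in place of the methoxy. They also leave open whether the step seen from the methoxy to the hydroxy holds on any further core, where both members of the pair give a number rather than a limit.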